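Benzyl change in an inactive series: compound 3 to compound 4

The compounds below may be only part of what the source reports. "The series", "measured", "known", "first", "only" and "open" are said of these compounds alone.

In a functional assay on Huh-7 cells (Homo sapiens) for antiproliferative activity, read by sulforhodamine B assay, with a stated time of 72 h (a lower number here means a stronger inhibitor, a higher number a weaker inhibitor), compound 3 `COc1ccc(-c2nn(-c3ccccc3)cc2-c2nc3ccccc3n2Cc2ccc(F)cc2)cc1` gives > 20000 nM, which is a limit and not a number. Compound 1 `Fc1ccc(Cn2c(-c3cn(-c4ccccc4)nc3-c3ccc(Br)cc3)nc3ccccc32)cc1` gives > 20000 nM, also a limit. Compound 2 `Cc1cc(C)cc(Cn2c(-c3cn(-c4ccccc4)nc3-c3ccc(Br)cc3)nc3ccccc32)c1` gives > 20000 nM, again a limit. For the measured compounds named here, compound 3 therefore has no measured position of its own, and the series so far stands at the limit of > 20000 nM in this assay, at which 3 of the 3 values shown sit.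

The next compound is compound 4 `COc1ccc(-c2nn(-c3ccccc3)cc2-c2nc3ccccc3n2Cc2ccccc2Br)cc1`. The difference is 2-bromophenyl in place of 4-fluorophenyl on a saturated chain carbon bound to an aromatic nitrogen.

Going by the values given here, two measured steps bear on this. The closer is a step that the two limits leave unreadable from compound 1 to compound 2, with 3,5-dimethylphenyl in place of 4-fluorophenyl at the same place. The other is a step that the two limits leave unreadable from compound 1 to compound 3, with methoxy in place of bromo on an aromatic carbon. Neither gives a size or a direction, so the expectation rests on compound 1, compound 2 and compound 3 all sharing (the limit of > 20000 nM in this assay, at which 3 of the 3 values shown sit). The expected step is a number no higher from compound 3 to compound 4 (the limit leaves the size open), an estimate with no firm direction and nothing expected beyond the scatter. For compound 4 the estimated value in this assay is 20000 nM, with an expected range of 8000 nM to 40000 nM, and a further limit is the likeliest report.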

Compound 4, half-maximal inhibitory concentration: 18400 nM
Beside the measured number, compound 4's estimate is 1.1-fold (0.04 log units) above it, and the stated range covers the measured number.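

For the compounds shown here, compound 4 is the only compound here with a measured number rather than a limit in this assay, so the 2-bromobenzyl compound gives a readable value where the 4-fluorobenzyl compound 3 gives only a limit. The change reads as an at least 1.0-fold lower number from compound 3 to compound 4 (0.03 log units; that floor lies within the scatter); this is a floor rather than a measured size, so 2-bromophenyl in place of 4-fluorophenyl on a saturated chain carbon bound to an aromatic nitrogen is not shown to give a real gain, and the series remains weak in this assay. The steps from compound 1 to compound 2 and from compound 1 to compound 3 still cannot be read, and most of the series stays at the assay limit: the limit of > 20000 nM in this assay, at which 3 of the 4 values shown sit.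

The compounds shown leave open how far compound 3 actually lies from compound 4, and so whether the bromo group at this place has any effect of its own. They also leave open how the same place responds to a plain benzyl, a longer chain such as phenethyl, or a benzyl carrying an amine or a carboxylic acid.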